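The source may hold more compounds than are shown below. What is called first, only, known or untested is meant among the compounds shown, and "the series" means these compounds.

Measured in a functional assay on HT-29 cells (Homo sapiens) for inhibition, read by MTT assay, with a stated time of 3 days; on this read-out higher numbers stand for weaker inhibition and lower numbers for stronger inhibition:
compound 1 `C/C=C/COc1cc(/C=C\c2cc(OC)c(OC)c(OC)c2)ccc1OC`: 161000 nM
compound 2 `COc1ccc(/C=C\c2cc(OC)c(OC)c(OC)c2)cc1OCc1ccccc1`: 39000 nM
compound 3 `COCOc1cccc(/C=C/CCCOc2cc(/C=C\c3cc(OC)c(OC)c(OC)c3)ccc2OC)c1`: 59000 nM

Compound 3 sits within the scatter of compound 2, and its number lies clearly below that of compound 1. The next compound to be tested in this assay is compound 4 `COc1ccc(/C=C\c2cc(OC)c(OC)c(OC)c2)cc1OCCC/C=C/c1ccc(Cl)cc1`. It carries 4-chlorophenyl in place of 3-(methoxymethoxy)phenyl on a double-bonded chain carbon bound to a double-bonded chain carbon.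

Going by the values given here, no measured step makes this exact exchange. The nearest evidence is a 4.1-fold lower number from compound 1 to compound 2 (0.62 log units; beyond the scatter), a modest step beyond the scatter, made by putting phenyl in place of prop-1-en-1-yl on a saturated chain carbon bound to an oxygen on an aromatic ring. That change swaps a different group at a different place, so it offers only weak guidance. Both aromatic groups here also end a long chain, so no clear direction is expected, and no step beyond the scatter is anticipated. The estimate is a 1.3-fold lower number from compound 3 to compound 4 (0.12 log units; within the scatter). For compound 4 the expected value is 45000 nM, with an estimated range of 15000 nM to 130000 nM.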

Compound 4, half-maximal inhibitory concentration: 18000 nM
For compound 4 the middle estimate is 2.5-fold (0.40 log units) above the measured one; low and high end bracket the measured number.
By their numbers in this assay, from the lowest: compound 4; then compounds 2 and 3 (each within the scatter of the next); then compound 1.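

In this assay, the group at the end of the long chain proves to matter: 4-chlorophenyl in place of 3-(methoxymethoxy)phenyl on a double-bonded chain carbon bound to a double-bonded chain carbon gives a step beyond the scatter (a 3.3-fold lower number from compound 3 to compound 4 (0.52 log units; beyond the scatter)). On the saturated chain carbon bound to an oxygen on an aromatic ring, 4-(4-chlorophenyl)but-3-en-1-yl also reads lower than phenyl (a 2.2-fold lower number from compound 2 to compound 4 (0.34 log units; beyond the scatter)) and lower than prop-1-en-1-yl (an 8.9-fold lower number from compound 1 to compound 4 (0.95 log units; beyond the scatter)), the last being the largest step in this set. No measurement shown here accounts for these differences.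

The compounds shown do not separate the effect of adding the chlorine from that of removing the methoxymethoxy group. They also leave open how an amine or a carboxylic acid on that phenyl ring would read, or a longer chain.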